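Isopropyl in place of 2-hydroxyethyl on the sulfonamide nitrogen

The source may report more compounds than this note shows. Statements on the series, on what has been measured and on what is new or still open speak of the compounds shown alone.

Compound 2 `CC1(C)C=C(n2ccccc2=O)c2cc(S(=O)(=O)NCCO)ccc2O1` holds the higher of the two numbers measured in a functional assay on the whole organism (aorta) with Rattus norvegicus as the target (on this read-out higher numbers stand for larger maximal responses and lower numbers for smaller maximal responses), where compound 2 reaches 95.5%. Compound 1 `CC1(C)C=C(n2ccccc2=O)c2cc(S(N)(=O)=O)ccc2O1` reaches 77.5% in this assay. Compound 3 `CC(C)NS(=O)(=O)c1ccc2c(c1)C(n1ccccc1=O)=CC(C)(C)O2` differs from compound 2 by isopropyl in place of 2-hydroxyethyl on a sulfonamide nitrogen. Among the measured compounds shown here, no measured step covers this exchange directly; the only step available, a number 18 percentage points higher from compound 1 to compound 2 (beyond the scatter), shows that a group on the sulfonamide nitrogen went with a larger response, but nothing shows how 2-hydroxyethyl compares with isopropyl. A small decrease, or none beyond the scatter, is therefore expected, a number 9.5 percentage points lower from compound 2 to compound 3 (within the scatter). Compound 3 is estimated at 86%, ranging from 68% to 100%.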

Compound 3, largest response reached (Emax), in percent of the reference or control that the assay uses: 76.9%
Compound 3: the middle estimate sits 9.1 percentage points above what was measured; measured number inside the range.
By their numbers in this assay, from the lowest: compounds 3 and 1 (each within the scatter of the next); then compound 2.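

In this assay, the larger response of compound 2 turns out not to come with just any group on the sulfonamide nitrogen: exchanging 2-hydroxyethyl for isopropyl costs the gain (a number 18.6 percentage points lower from compound 2 to compound 3 (beyond the scatter)), and isopropyl in place of hydrogen leaves the number level (a number 0.6 percentage points lower from compound 1 to compound 3 (within the scatter)). Among these three compounds, the gain therefore appears only with 2-hydroxyethyl. No evidence is available to explain this difference. As far as these compounds go, whether it would persist with a 2-methoxyethyl group, a longer hydroxyalkyl chain or a 2-aminoethyl group on that nitrogen remains open.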